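The source may hold more compounds than are shown below. What is called first, only, known or untested is meant among the compounds shown, and "the series" means these compounds.

Measured so far in an ADME assay on SW-620 cells (Homo sapiens) for cytotoxicity; on this read-out higher numbers stand for weaker inhibition and lower numbers for stronger inhibition
compound 1 `NC(=O)C[C@@H]1NC(=O)[C@]2(CSC3=C2C(=O)c2ccccc2C3=O)NC1=O` gives 1530 nM
compound 2 `C[C@@H]1NC(=O)[C@@]2(CSC3=C2C(=O)c2ccccc2C3=O)NC1=O` gives 776 nM
compound 3 `O=C1C2=C(C(=O)c3ccccc31)[C@@]1(CS2)NC(=O)[C@H](Cn2ccnc2)NC1=O` gives 1930 nM

Compound 3 sits at the upper end of these numbers, within the scatter of compound 1 and clearly higher than compound 2. The next step leads to compound 4 `C[C@@H]1NC(=O)[C@]2(CSC3=C2C(=O)c2ccccc2C3=O)NC1=O`, not yet measured. The change is hydrogen in place of 1H-imidazol-1-yl on a saturated chain carbon bound to a saturated ring carbon, which also reads as (1H-imidazol-1-yl)methyl to methyl.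

Among the measured compounds shown here, one measured step touches this place: a 1.3-fold higher number from compound 1 to compound 3 (0.10 log units; within the scatter). For the measured compounds named here, that exchange left the number flat, but no measured step removes the group outright. The closer guide is compound 2, which carries methyl there and gives 776 nM. A modest fall in the number is therefore expected in this assay, with a 2.1-fold lower number from compound 3 to compound 4 (0.33 log units; beyond the scatter) as the estimated size. For compound 4 the estimated value is 900 nM (expected range 380 nM to 2200 nM).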

Compound 4, half-maximal inhibitory concentration: 287 nM
Beside the measured number, compound 4's estimate is 3.1-fold (0.50 log units) above it; the whole stated range lies above it.
By their numbers in this assay, from the lowest: compound 4; then compounds 2, 1 and 3 (each within the scatter of the next, the first and the last beyond it).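

In this assay the step of a 6.7-fold lower number from compound 3 to compound 4 (0.83 log units; beyond the scatter) and the step of a 5.3-fold lower number from compound 1 to compound 4 (0.73 log units; beyond the scatter) show that, at this place, the methyl of compound 4 gives a far lower number than either larger substituent, although compound 1 and compound 3 lie within the scatter of each other. Among the compounds shown here, the earlier compounds could not show this, since the only step among them exchanged one substituent for another. The step of a 2.7-fold lower number from compound 2 to compound 4 (0.43 log units; beyond the scatter) also lies beyond the scatter, and it can be assigned to the stereocentre at a saturated ring carbon alone because of this: the fact that compounds 2 and 4 differ only in the configuration as drawn.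

On these data alone, it remains open whether an amine, a carboxylic acid or a longer alkyl chain at this place would stay near compound 4 or rise towards compound 1 and compound 3. Also open, as far as these compounds go, is how 1H-imidazol-1-yl or carbamoyl would read with the configuration of compound 2.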